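Aminoquinoline ethers: swapping the ether side chain

The compounds below may be only part of what the source reports. "The series", "measured", "known", "first", "only" and "open" are said of these compounds alone.

Two ethers on a shared core have been measured. Compound 1 `Nc1ccc2cccc(OC3CCCCCC3)c2n1` gives 137 nM in an assay on cells with melanin-concentrating hormone receptor 1 (Homo sapiens) as the target, read by radioligand binding; on this read-out lower numbers stand for stronger inhibition and higher numbers for weaker inhibition. For the measured compounds named here, compound 2 `CCOCC(C)Oc1cccc2ccc(N)nc12` gives 1070 nM in this assay, the highest of the two numbers so far; its nearest neighbour is compound 1, and the gap between them lies beyond the usual scatter.

The next compound, compound 3 `CC(C)=CCOc1cccc2ccc(N)nc12`, differs from compound 2 in one place: a group of 5 heavy atoms (5 carbon; no ring) in place of a group of 6 heavy atoms (5 carbon, 1 oxygen; no ring), on an oxygen on an aromatic ring. The entering group is 3-methylbut-2-en-1-yl, with one double bond outside aromatic rings and no hydrogen-bond acceptor, in place of a chain carrying an oxygen. Going by the values given here, no step between measured compounds is available to calibrate this change; the only reference is that compound 1, with a ring-bearing ether group, sits at 137 nM.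

The estimate for compound 3 is a number below that of compound 2, at 350 nM with a range from 120 nM to 1000 nM. The expected step is a 3.1-fold lower number from compound 2 to compound 3 (0.49 log units; beyond the scatter), which would be beyond the scatter, though the wide range allows for a smaller move as well.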

Compound 3, half-maximal inhibitory concentration: > 2000 nM
Compound 3: a limit, no number; the forecaster's own chance of this, stated with the estimate: 3%; middle value at least 5.7-fold (0.75 log units) away from the limit.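

In this assay compound 3 gives > 2000 nM, a limit of the assay and not a number. Placing 3-methylbut-2-en-1-yl on this oxygen in place of the chain carrying an oxygen gives an at least 1.8-fold higher number from compound 2 to compound 3 (0.27 log units; that floor lies within the scatter), so the swap brings no gain on this read-out, while the true size of any loss stays unknown. This position therefore does not reward every all-carbon open chain, and the ring-bearing group of compound 1 still holds the lowest value shown, at 137 nM.

The compounds shown do not tell whether the oxygen in the chain of compound 2 matters in itself or whether the chain as a whole sets the value. From the compounds shown here alone, how an amine or a carboxylic acid on the chain, or a longer chain, would read at this position also remains open.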